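Compound 3 and a New Chain End

A few compounds are considered here, and "the series" means these few. Any claim that something is new, unique, unknown or untested is made for them only; others in the source may bear on it.

Of the compounds shown here, three built on one shared core have been measured so far. In a functional assay on MCF7 cells (Homo sapiens) for antiproliferative activity, read by MTT assay, with a stated time of 24 h (on this read-out higher numbers stand for weaker inhibition and lower numbers for stronger inhibition), compound 1 `CCCCc1oc2ccccc2c1C(=O)c1ccc(OCC(=O)Nc2ccccc2)cc1` gives 33600 nM, compound 2 `CCCCc1oc2ccccc2c1C(=O)c1ccc(OCC(=O)Nc2cccc(OC)c2)cc1` gives 38500 nM and compound 3 `CCCCc1oc2ccccc2c1C(=O)c1ccc(OCC(=O)NCc2ccccc2)cc1` gives 19600 nM. Compound 3 stands level with the other two. Its measured steps are a 1.7-fold lower number from compound 1 to compound 3 (0.23 log units; within the scatter) and a 2.0-fold lower number from compound 2 to compound 3 (0.29 log units; within the scatter), and neither leaves the scatter.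

The next structure is compound 4 `CCCCc1oc2ccccc2c1C(=O)c1ccc(OCCCC(=O)N2CCCC2)cc1`. Its change from compound 3 is 2-((pyrrolidin-1-yl)carbonyl)ethyl in place of benzylcarbamoyl on a saturated chain carbon bound to an oxygen on an aromatic ring. Cut one bond further out, the same difference reads (benzylcarbamoyl)methyl to 3-((pyrrolidin-1-yl)carbonyl)propyl.

The nearest guides are the two changes on the amide-type nitrogen shown above. The methoxy change adds a third small step, a 1.1-fold higher number from compound 1 to compound 2 (0.06 log units; within the scatter). None of the three measured compounds carries a 3-((pyrrolidin-1-yl)carbonyl)propyl group, so the data cannot show directly what this larger replacement does. With only small steps to go on, no change beyond the scatter is expected, and the wide range below allows for this gap. The expected step is a 1.3-fold higher number from compound 3 to compound 4 (0.11 log units; within the scatter). For compound 4 the estimate is 25000 nM, with an expected range from 10000 nM to 60000 nM.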

Compound 4, half-maximal inhibitory concentration: 23500 nM
Beside the measured number, compound 4's estimate is 1.1-fold (0.03 log units) above it; low and high end bracket the measured number.
By their numbers in this assay, from the lowest: compounds 3, 4, 1 and 2 (each within the scatter of the next).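

For the compounds shown here, compound 4 is the first compound here whose chain ends in a five-membered non-aromatic ring, and its amide has no hydrogen-bond donor, while the amides of compounds 1, 2 and 3 each carry one. Even so, this assay shows no shift beyond the scatter against any of the three, with the benzylcarbamoyl group of compound 3 giving way to 2-((pyrrolidin-1-yl)carbonyl)ethyl (a 1.2-fold higher number from compound 3 to compound 4 (0.08 log units; within the scatter)), the (3-methoxyphenyl)carbamoyl group of compound 2 giving way to the same group (a 1.6-fold lower number from compound 2 to compound 4 (0.21 log units; within the scatter)), and the phenylcarbamoyl group of compound 1 doing so too (a 1.4-fold lower number from compound 1 to compound 4 (0.16 log units; within the scatter)). So this position accepts a change in chain length, ring and donor count all at once without leaving the scatter, and nothing measured here offers an explanation for that.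

Chain length and chain end change together in compound 4, so a benzylcarbamoyl group on the longer chain, or a (pyrrolidin-1-yl)carbonyl group on the shorter one, would be needed to tell them apart. Going by these compounds, whether a carboxylic acid or an amine at the chain end would give a step beyond the scatter also stays open.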